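This account rests on a few compounds, and the source may have more. Where it says the series, first, only, none or still open, it means among the compounds named here.

Compound 1 `COc1ccc(Nc2cc(NC(=O)c3ccccc3)ncn2)cc1`, compound 2 `O=C(O)CCCC(=O)Nc1cc(Nc2cccc(Br)c2)ncn1` and compound 3 `CCOC(=O)CCC(=O)Nc1cc(Nc2cccc(Br)c2)ncn1` share one core. In an assay for inhibition of Receptor tyrosine-protein kinase erbB-3 variant L858R (Homo sapiens), read by mobility shift assay, with a stated time of 10 min (a lower number here means a stronger inhibitor, a higher number a weaker inhibitor), compound 1 gives 60 nM, and compound 3 gives 1350 nM. Compound 2 reaches only a limit of this assay, > 10000 nM, so where it stands among the numbers shown is a limit and not a value (the limit of > 10000 nM in this assay, at which 1 of the 3 values shown sits). For the measured compounds named here, the single measured step, an at least 7.4-fold lower number from compound 2 to compound 3 (0.86 log units; beyond the scatter), concerns the chain end and not the aromatic ring. Compound 4 `O=C(O)CCCC(=O)Nc1cc(Nc2ccccc2)ncn1` differs from compound 2 by hydrogen in place of bromo on an aromatic carbon. Going by the values given here, no measured step bears on this aromatic change, so only a small expected step, a step that the limit leaves unreadable from compound 2 to compound 4, is foreseen. Compound 4 is therefore estimated at 15000 nM, within a range from 4000 nM to 60000 nM.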

Compound 4, half-maximal inhibitory concentration: 183 nM
For compound 4 the middle estimate is 82-fold (1.91 log units) above the measured one; measured number outside the range, below it.
By their numbers in this assay, from the lowest: compound 1; then compound 4; then compound 3. At a limit, above all of these: compound 2.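

The bromo on the aromatic carbon turns out to matter strongly on this chain: the change from 3-bromophenyl to phenyl gives an at least 54-fold lower number from compound 2 to compound 4 (1.73 log units; beyond the scatter). Compound 2 stands at a limit of this assay, > 10000 nM, and that is not a number. Compound 4 keeps the same carboxylic acid chain and gives 183 nM, so this chain end does not by itself fix a high number.

As far as these compounds go, whether chloro or methyl at this place would behave like bromo remains open. So does whether the same change would carry over to the ethyl ester chain of compound 3.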